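The compounds below may be only part of what the source reports. "The series", "measured", "known", "first", "only" and "open" are said of these compounds alone.

Compound 1, `CCCCCCCCCCCCNC(=O)[C@@H]1CSC(c2ccc(NC(C)=O)cc2)N1`, gives 1200 nM in a functional assay on WM164 cells (Homo sapiens) for antiproliferative activity, read by sulforhodamine B assay, with a stated time of 48 h; a higher number here means a weaker inhibitor, a lower number a stronger inhibitor.
Compound 2, `CCCCCCCCCCCCCCNC(=O)[C@@H]1CSC(c2ccc(NC(C)=O)cc2)N1`, gives 600 nM in this assay.
Compound 3, `CCCCCCCCCCCCCCNC(=O)[C@@H]1CSC(c2ccccc2)N1`, gives 600 nM in this assay.

The change ethyl in place of hydrogen on a saturated chain carbon, ten or more bonds along the chain from an amide-type nitrogen produced a 2.0-fold lower number from compound 1 to compound 2 (0.30 log units; within the scatter). Taking away the acetamido group gave no change at the digits printed from compound 2 to compound 3 (within the scatter). The difference between the core of compound 1 and the core of compound 3 is not broken down here.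

Compound 4, `CCCCCCCCCCCCCCCCNC(=O)[C@@H]1CSC(c2ccccc2)N1`, is the member still to be measured. It differs from compound 3 by ethyl in place of hydrogen on a saturated chain carbon, ten or more bonds along the chain from an amide-type nitrogen, the same change as that made between compound 1 and compound 2, at the same place. Because the earlier step of a 2.0-fold lower number from compound 1 to compound 2 (0.30 log units; within the scatter) was small, the expected step to compound 4 is a 1.5-fold lower number from compound 3 to compound 4 (0.18 log units; within the scatter). Compound 4 is estimated at 400 nM, expected to fall between 150 nM and 900 nM.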

Compound 4, half-maximal inhibitory concentration: 700 nM
Estimate against measurement, compound 4: 1.8-fold (0.24 log units) below, within the range that was stated.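

In this assay the added ethyl gave a 1.2-fold higher number from compound 3 to compound 4 (0.07 log units; within the scatter). Set beside the earlier step, the same change on the two cores gives steps that cannot be told apart: the same change on two cores in this assay, a 2.0-fold lower number (0.30 log units; within the scatter) from compound 1 to compound 2 and a 1.2-fold higher number (0.07 log units; within the scatter) from compound 3 to compound 4, 2.3-fold (0.37 log units) apart, within the scatter of two such steps. This shows that the change carries between these two cores with no difference that can be read, but it does not show that the ethyl has a real effect on either core, and one pair on each core says nothing about a third.

The compounds shown leave open whether a much shorter or much longer chain would give a step beyond the scatter. They also leave open what methoxy or fluorine in place of acetamido would give.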